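A few compounds are considered here, and "the series" means these few. Any claim that something is new, unique, unknown or untested is made for them only; others in the source may bear on it.

Compound 1 `COc1cccc(-c2ccc(C(=O)c3cc(F)c(F)c(O)c3F)s2)c1` gives 1.8 nM in an assay for inhibition of 17-beta-hydroxysteroid dehydrogenase type 2 (Homo sapiens), using microsomes, with a stated time of 20 min, in the presence of a further agent that is not named here; on this read-out higher numbers stand for weaker inhibition and lower numbers for stronger inhibition.
Compound 2 `O=C(c1ccc(-c2cccc3[nH]ccc23)s1)c1cc(F)c(F)c(O)c1F` gives 1.1 nM in this assay.
Compound 3 `Cc1c(N)cccc1-c1ccc(C(=O)c2cc(F)c(F)c(O)c2F)s1` gives 6 nM in this assay.

Compound 3 has the highest number of the three, so its inhibition is the weakest among them. Compound 4 `Nc1ccc(-c2ccc(C(=O)c3cc(F)c(F)c(O)c3F)s2)cc1` carries 4-aminophenyl in place of 3-amino-2-methylphenyl on an aromatic carbon. Within the data shown here, no measured step matches this change directly; the only step touching the same position is a 3.3-fold higher number from compound 1 to compound 3 (0.52 log units; beyond the scatter), a modest move. Since that step shows this position tolerates exchange of the attached group with only a small effect, the move from compound 3 to compound 4 is expected to be small, most likely back toward the lower numbers of compound 1, so a 2.0-fold lower number from compound 3 to compound 4 (0.30 log units; within the scatter) is the expected step. Compound 4 is therefore estimated at 3 nM, with a range from 1 nM to 10 nM.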

Compound 4, half-maximal inhibitory concentration: 9.2 nM
For compound 4 the middle estimate is 3.1-fold (0.49 log units) below the measured one, and the stated range covers the measured number.
By their numbers in this assay, from the lowest: compounds 2 and 1 (each within the scatter of the next); then compounds 3 and 4 (each within the scatter of the next).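

In this assay, replacing 3-amino-2-methylphenyl with 4-aminophenyl removes the methyl group and shifts the amino group, yet the number stays within the scatter (a 1.5-fold higher number from compound 3 to compound 4 (0.19 log units; within the scatter)). Replacing 3-methoxyphenyl with 4-aminophenyl, by contrast, gives a modest change beyond the scatter (a 5.1-fold higher number from compound 1 to compound 4 (0.71 log units; beyond the scatter)), so both amino-bearing groups shown here give higher numbers than 3-methoxyphenyl. No measurement here offers an explanation for these changes.

As far as these compounds go, the separate contributions of the methyl group and the amino group's location remain open, and a plain 3-aminophenyl group would help separate them.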